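Working notes: from compound 3 to compound 4

This account rests on a few compounds, and the source may have more. Where it says the series, first, only, none or still open, it means among the compounds named here.

- compound 1 `CNC(=O)c1cc(Oc2ccc(C(=O)/C=C/c3cccc(Br)c3)cc2)ccn1`: 3400 nM
- compound 2 `CNC(=O)c1cc(Oc2ccc(C(=O)/C=C/c3ccc(Cl)c(Cl)c3)cc2)ccn1`: 8260 nM
- compound 3 `CNC(=O)c1cc(Oc2ccc(C(=O)/C=C/c3ccc(C#N)cc3)cc2)ccn1`: 3870 nM

All three values come from a functional assay on PC-3 cells (Homo sapiens) for cytotoxicity, read by MTT assay, with a stated time of 72 h; a lower number here means a stronger inhibitor, a higher number a weaker inhibitor. Compound 3 stands level with compound 1 within the scatter, a 1.1-fold higher number from compound 1 to compound 3 (0.06 log units; within the scatter). Its only gap beyond the scatter is a 2.1-fold lower number from compound 2 to compound 3 (0.33 log units; beyond the scatter). The next change puts 2,4-dichlorophenyl in place of 4-cyanophenyl on a double-bonded chain carbon bound to a double-bonded chain carbon, giving compound 4 `CNC(=O)c1cc(Oc2ccc(C(=O)/C=C/c3ccc(Cl)cc3Cl)cc2)ccn1` (2,4-dichlorophenyl in place of 4-cyanophenyl on a double-bonded chain carbon bound to a double-bonded chain carbon). Going by the values given here, compound 2 is the only other dichlorophenyl member, so the modest 2.1-fold lower number from compound 2 to compound 3 (0.33 log units; beyond the scatter), read in reverse, is the nearest guide, and a 2.4-fold higher number from compound 1 to compound 2 (0.39 log units; beyond the scatter) points the same way. Chlorine placement differs, so a modest rise in the number is expected in this assay. The expected step is a 1.6-fold higher number from compound 3 to compound 4 (0.19 log units; within the scatter). For compound 4 the estimated value is 6000 nM, with a range of 2800 nM to 13000 nM.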

Compound 4, half-maximal inhibitory concentration: 9220 nM
Estimate against measurement, compound 4: 1.5-fold (0.19 log units) below; low and high end bracket the measured number.
By their numbers in this assay, from the lowest: compounds 1 and 3 (each within the scatter of the next); then compounds 2 and 4 (each within the scatter of the next).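

In this assay, the two dichlorophenyl patterns cannot be told apart: 2,4-dichlorophenyl in place of 3,4-dichlorophenyl gives a 1.1-fold higher number from compound 2 to compound 4 (0.05 log units; within the scatter). Against the single-substituent members, 2,4-dichlorophenyl gives a 2.4-fold higher number from compound 3 to compound 4 (0.38 log units; beyond the scatter) and a 2.7-fold higher number from compound 1 to compound 4 (0.43 log units; beyond the scatter), so among these four compounds both dichlorophenyl members carry the higher numbers, and no compound goes against this. No supporting data bear on why the numbers group this way.

Open, going by these compounds, is whether a phenyl group with a single chlorine, or an aminophenyl group, at this place would group with compound 1 and compound 3 or with compound 2 and compound 4.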